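Varying the Group on the Saturated Ring Carbon

The source may report more compounds than this note shows. Statements on the series, on what has been measured and on what is new or still open speak of the compounds shown alone.

Going by the values given here, compound 2 `Cc1cc(O)c(C2=NN(c3ccc(S(N)(=O)=O)cc3)C(/C=C/c3ccccc3)C2)cc1Cl` is one of two compounds measured in a functional assay on UACC-62 cells (Homo sapiens) for antiproliferative activity, with a stated time of 48 h (a higher number here means a weaker inhibitor of growth, a lower number a stronger inhibitor of growth), where compound 2 gives 2890 nM. Its companion, compound 1 `Cc1cc(O)c(C2=NN(c3ccc(S(N)(=O)=O)cc3)C(c3ccccc3Cl)C2)cc1Cl`, gives 3710 nM in this assay. Among the compounds with values here, the step of a 1.3-fold lower number from compound 1 to compound 2 (0.11 log units; within the scatter) is the only measured comparison, so compound 2 shows the lower of the two numbers without standing apart from compound 1 beyond the scatter. Compound 3 `COc1ccc(C2CC(c3cc(Cl)c(C)cc3O)=NN2c2ccc(S(N)(=O)=O)cc2)c(OC)c1OC` has not yet been measured. Within the data shown here, it differs from compound 2 at the same position that the one measured step altered: 2,3,4-trimethoxyphenyl in place of 2-phenylethenyl on a saturated ring carbon. Because a 1.3-fold lower number from compound 1 to compound 2 (0.11 log units; within the scatter) stayed within the scatter at this same position, there is no basis for expecting a large shift in this assay in either direction, although the entering group is larger and carries three acceptors, which the measured pair did not test. Compound 3 is therefore estimated to give 2600 nM in this assay, with a likely range from 900 nM to 7500 nM. The step of a 1.1-fold lower number from compound 2 to compound 3 (0.05 log units; within the scatter) is expected to be small.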

Compound 3, concentration for 50% growth inhibition: 2470 nM
Beside the measured number, compound 3's estimate is 1.1-fold (0.02 log units) above it, within the range that was stated.
By their numbers in this assay, from the lowest: compounds 3, 2 and 1 (each within the scatter of the next).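

Compound 3 puts a group with 3 hydrogen-bond acceptors at this position, something the earlier pair did not test, and in this assay the exchange for 2-phenylethenyl gives a 1.2-fold lower number from compound 2 to compound 3 (0.07 log units; within the scatter) while the exchange for 2-chlorophenyl gives a 1.5-fold lower number from compound 1 to compound 3 (0.18 log units; within the scatter). So 2-chlorophenyl, 2-phenylethenyl and 2,3,4-trimethoxyphenyl, which differ in size and in acceptors, leave compound 1, compound 2 and compound 3 within the scatter of one another. Nothing measured here explains why this position shows so little change.

On these data alone, whether an amine, a carboxylic acid or a small group such as methyl on this saturated ring carbon would move the number remains open. All the compounds shown keep the 4-sulfamoylphenyl and 5-chloro-2-hydroxy-4-methylphenyl groups, so the effect of changing either one is also unknown.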